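Replacing 4-chlorophenyl in compound 3: working notes

The source may hold more compounds than are shown below. What is called first, only, known or untested is meant among the compounds shown, and "the series" means these compounds.

Measured in a functional assay on A549 cells (Homo sapiens) for inhibition, read by CCK-8 assay, with a stated time of 48 h; on this read-out lower numbers stand for stronger inhibition and higher numbers for weaker inhibition:
- compound 1 `COc1cc(-c2cc3nccc(-c4cc(OC)c(OC)c(OC)c4)n3n2)cc(OC)c1OC` gives > 10000 nM as a limit
- compound 2 `COc1cc(-c2cc3nccc(-c4c[nH]c5ccccc45)n3n2)cc(OC)c1OC` gives > 10000 nM as a limit
- compound 3 `COc1cc(-c2ccnc3cc(-c4ccc(Cl)cc4)nn23)cc(OC)c1OC` gives 3070 nM

Within the data shown here, compound 3 holds the only true number in the set so far. The other two entries are not numbers, and they mark (the limit of > 10000 nM in this assay, at which 2 of the 3 values shown sit). Compound 3 is therefore the sole numerical anchor for this series.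

The next compound to be tested is compound 4 `COc1cc(-c2ccnc3cc(-c4ccc5c(ccn5C)c4)nn23)cc(OC)c1OC`. Its structure departs from compound 3 in one place: 1-methyl-1H-indol-5-yl in place of 4-chlorophenyl on an aromatic carbon. The 1-methyl-1H-indol-5-yl group thus takes the place of 4-chlorophenyl, and the rest of the molecule stays the same.

Among the measured compounds shown here, no two measured compounds differ in one place, so the data give no measured step to serve as a guide. Compounds 1 and 2 also differ from compound 3 in how their groups are arranged on the shared core, so they say little about this change. With compound 3 at 3070 nM as the starting point, a clear step toward stronger inhibition in this assay is expected, though this is a judgement with wide uncertainty. The expected change is a 10-fold lower number from compound 3 to compound 4 (1.01 log units; beyond the scatter). For compound 4 the estimated value is 300 nM, with an expected range from 15 nM to 4000 nM.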

Compound 4, half-maximal inhibitory concentration: 15 nM
Compound 4: middle estimate off by 20-fold (1.30 log units), on the high side; measured number inside the range.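

In this assay, the aromatic carbon of the five-membered aromatic ring with 2 nitrogen now has its first measured step: 1-methyl-1H-indol-5-yl in place of 4-chlorophenyl gives a 200-fold lower number from compound 3 to compound 4 (2.31 log units; beyond the scatter). Among these compounds, this shows that, with the rest of the molecule unchanged, the group at this one place can move the number by a large margin, which no earlier pair could show. Compounds 1 and 2 are limits and not numbers, so no steps from them can be read: the limit of > 10000 nM in this assay, at which 2 of the 4 values shown sit.

Which part of the entering group carries the step stays open: it brings a second aromatic ring, a ring nitrogen and an N-methyl group together, and one pair cannot separate them or give a cause. How an unsubstituted phenyl, a benzofuran-5-yl or a 1H-indol-5-yl lacking the methyl group would read at this place also remains an open question, as does whether the step would hold with other changes elsewhere on the shared core.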